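Swapping 3-bromophenyl for 2,4-dimethylphenyl on a shared core

The source may report more compounds than this note shows. Statements on the series, on what has been measured and on what is new or still open speak of the compounds shown alone.

compound 1 `CC(C)=CCOc1ccc2c(c1)OC(c1ccc(F)cc1)CC2=O` gives 7320 nM
compound 2 `CC(C)=CCOc1ccc2c(c1)OC(c1ccc(Cl)cc1)CC2=O` gives 6970 nM
compound 3 `CC(C)=CCOc1ccc2c(c1)OC(c1cccc(Br)c1)CC2=O` gives 5280 nM

These three compounds share one core and differ only in the halogen-bearing aromatic group. In a functional assay (a higher number here means a weaker inhibitor, a lower number a stronger inhibitor), compound 3 gives 5280 nM and stands level with the other two, with a 1.3-fold lower number from compound 2 to compound 3 (0.12 log units; within the scatter) and a 1.4-fold lower number from compound 1 to compound 3 (0.14 log units; within the scatter) as its steps.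

Compound 4 `CC(C)=CCOc1ccc2c(c1)OC(c1ccc(C)cc1C)CC2=O` has 2,4-dimethylphenyl in place of 3-bromophenyl on a saturated ring carbon. Among the measured compounds shown here, the only guidance comes from earlier swaps of this same group. Besides the two steps above, there is a 1.1-fold lower number from compound 1 to compound 2 (0.02 log units; within the scatter) as a third. All three are small, so this group has not yet moved the number in any measured pair. However, none of the measured compounds carries a dimethylphenyl group, so this evidence reaches the new group only indirectly, and the range has to stay wide. No step beyond the scatter is therefore expected in this assay, and no direction is favoured. The expected outcome is a 1.1-fold higher number from compound 3 to compound 4 (0.06 log units; within the scatter) and this remains only an estimate. For compound 4 the estimated value is 6000 nM with an expected range from 2800 nM to 13000 nM in this test.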

Compound 4, half-maximal inhibitory concentration: 8260 nM
Compound 4: middle estimate off by 1.4-fold (0.14 log units), on the low side, and the stated range covers the measured number.
By their numbers in this assay, from the lowest: compounds 3, 2, 1 and 4 (each within the scatter of the next).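

In this assay, among the compounds shown here, the 2,4-dimethylphenyl group is the first group at this position to carry no halogen and to have two groups on its ring, yet every new step stays within the scatter (a 1.6-fold higher number from compound 3 to compound 4 (0.19 log units; within the scatter); a 1.2-fold higher number from compound 2 to compound 4 (0.07 log units; within the scatter); a 1.1-fold higher number from compound 1 to compound 4 (0.05 log units; within the scatter)). The aromatic group on the saturated ring carbon next to the ring oxygen can therefore change in both of these ways without a clear change in the number, at least across these four compounds on the shared core. Nothing available here explains this flat result.

All four compounds shown carry an aromatic ring of carbon only at this position, so it remains open whether a pyridine ring, an amine or a carboxylic acid in its place would leave the number in this assay where it is or shift it beyond the scatter. As far as these compounds go, it also remains open whether any change at this position can separate compounds in this assay, or whether a clear step would have to come from another part of the shared core.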